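A Fluoro Substituent on the Saturated Ring: Compound 3

This account rests on a few compounds, and the source may have more. Where it says the series, first, only, none or still open, it means among the compounds named here.

Compound 1 `CN(Cc1ccccc1)C1CCN(CCCc2c[nH]c3ccc(-n4cnnc4)cc23)CC1` — 94%
Compound 2 `c1ccc(CC2CCN(CCCc3c[nH]c4ccc(-n5cnnc5)cc34)CC2)cc1` — 62%

Both compounds were measured in a functional assay on CHO cells with 5-hydroxytryptamine receptor 1D (Homo sapiens) as the target; on this read-out higher numbers stand for larger maximal responses and lower numbers for smaller maximal responses. Compound 2 holds the lower of the two numbers, and its nearest neighbour is compound 1. Within the data shown here, the single measured step, a number 32 percentage points lower from compound 1 to compound 2 (beyond the scatter), accompanied benzyl in place of benzyl(methyl)amino on a saturated ring carbon and is described as beyond the scatter.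

Compound 3 `FC1(Cc2ccccc2)CCN(CCCc2c[nH]c3ccc(-n4cnnc4)cc23)CC1` has not yet been measured. It differs from compound 2 in one place:

fluoro in place of hydrogen on a saturated ring carbon

Among the measured compounds shown here, no measured step bears directly on this change. The step from compound 1 to compound 2 concerns the exchange of an amino group for a hydrocarbon group on that ring carbon, not the addition of a fluoro group, so it offers no guide to the direction or size of the present change. With nothing measured to suggest a shift, the expected step is no change at the digits printed from compound 2 to compound 3 (within the scatter), that is, none beyond the scatter, though the range is kept wide for lack of precedent. Compound 3 is therefore estimated to give 62% in this assay, between 42% and 82%.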

Compound 3, largest response reached (reported as efficacy), in percent of the reference or control that the assay uses: 58%
Compound 3: middle estimate off by 4 percentage points, on the high side; low and high end bracket the measured number.
By their numbers in this assay, from the lowest: compounds 3 and 2 (each within the scatter of the next); then compound 1.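

In this assay, fluoro in place of hydrogen on a saturated ring carbon, three ring bonds from the ring nitrogen, came with a number 4 percentage points lower from compound 2 to compound 3 (within the scatter), so compound 2 and compound 3 cannot be told apart on this read-out. The earlier step, a number 32 percentage points lower from compound 1 to compound 2 (beyond the scatter), had shown that exchanging the benzyl(methyl)amino group for benzyl on a saturated ring carbon goes with a response difference beyond the scatter, whereas this new step shows that a single fluorine atom on that ring carbon does not. Nothing available explains why the maximal response of compound 3 stays within the scatter of that of compound 2.

The compounds shown leave open whether a hydroxyl group, a methyl group or an amine in the same place, with the benzyl group kept, would also stay within the scatter of compound 2. They also leave open whether a longer chain in place of benzyl, such as phenethyl, would tolerate fluoro equally well, or whether a second amine elsewhere on the benzyl group would bring the response nearer to that of compound 1.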